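A few compounds are considered here, and "the series" means these few. Any claim that something is new, unique, unknown or untested is made for them only; others in the source may bear on it.

Measured to date:
- compound 1, `COc1ccc2ncc(S(=O)(=O)c3ccc(C)c(F)c3)c(N3CCC(C)CC3)c2c1`: 73%
- compound 2, `COc1ccc2ncc(S(=O)(=O)c3ccc(Cl)c(Cl)c3)c(N3CCC(C)CC3)c2c1`: 87%
- compound 3, `CC1CCN(c2c(S(=O)(=O)c3ccc(F)cc3)cnc3ccc(F)cc23)CC1`: 87%

In an assay on isolated protein for displacement of a labelled ligand from metabotropic glutamate receptor 5 (Homo sapiens), with a stated time of 60 min, tested at 1 uM (on this read-out higher numbers stand for more inhibition at the one concentration tested (going by the name of the read-out) and lower numbers for less inhibition), compound 3 stands level with compound 2 at the digits shown, the two together highest of the three numbers, and it sits above compound 1 by a margin beyond the scatter. Among the compounds with values here, the one single-point step measured in this assay, a number 14 percentage points higher from compound 1 to compound 2 (beyond the scatter), concerns the aryl group on the sulfonyl sulfur, not the core, so it does not bear on the change now at hand.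

Compound 4, `COc1ccc2ncc(S(=O)(=O)c3ccc(F)cc3)c(N3CCC(C)CC3)c2c1`, differs from compound 3 by methoxy in place of fluoro on an aromatic carbon. Within the data shown here, no measured pair isolates this change. The nearest guidance comes from the two measured compounds that carry the same methoxy core as compound 4. In this assay compound 1 gives 73% and compound 2 gives 87%, a range that brackets the value of compound 3. Therefore a step of about a number 5 percentage points lower from compound 3 to compound 4 (within the scatter) is expected. Compound 4 is estimated at 82%, with a range of 65% to 93%.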

Compound 4, a percentage reported as inhibition, at one concentration (the size of the read-out at that concentration, not a potency): 27%
Compound 4: middle estimate off by 55 percentage points, on the high side, and the stated range ends above it.
By their numbers in this assay, from the lowest: compound 4; then compound 1; then compounds 2 and 3 (each within the scatter of the next).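

In this assay, methoxy in place of fluoro at this position, on the aromatic carbon para to a fused ring, gives a number 60 percentage points lower from compound 3 to compound 4 (beyond the scatter) with 4-fluorophenyl on the sulfonyl sulfur, so this single change can cost a large part of the inhibition. The methoxy core itself still allows high numbers, and on that core the sulfonyl aryl group weighs far more than a number 14 percentage points higher from compound 1 to compound 2 (beyond the scatter) suggested: 4-fluorophenyl gives a number 60 percentage points lower from compound 2 to compound 4 (beyond the scatter) and also a number 46 percentage points lower from compound 1 to compound 4 (beyond the scatter) in the same assay. No supporting data bear on why these steps are so large.

Whether the methoxy step keeps its size with 3,4-dichlorophenyl on the sulfonyl sulfur cannot be read from these compounds, since none pairs that group with the fluoro core. As far as these compounds go, how a hydroxyl or an ethoxy group would fare at this position also stays open.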